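Two limits and an untested piperidine amide

The compounds below may be only part of what the source reports. "The series", "measured", "known", "first", "only" and "open" are said of these compounds alone.

Both values measured so far are limits:
Compound 1 `C=C(C)C(=O)NCCOc1ccc(Oc2c(-c3ccc(F)cc3)sc3cc(O)ccc23)cc1`: > 25000 nM
Compound 2 `O=C(CCCNCCOc1ccc(Oc2c(-c3ccc(F)cc3)sc3cc(O)ccc23)cc1)N1CCC1`: > 25000 nM

In a functional assay on Ishikawa cells (Homo sapiens) for antiproliferative activity, read by CCK-8 assay, with a stated time of 48 h (a lower number here means a stronger inhibitor, a higher number a weaker inhibitor), compound 2 stands at > 25000 nM, which is a limit and not a number. For the measured compounds named here, the same holds for its only neighbour, as the record shows (the limit of > 25000 nM in this assay, at which 2 of the 2 values shown sit). Compound 3 `O=C(/C=C/CNCCOc1ccc(Oc2c(-c3ccc(F)cc3)sc3cc(O)ccc23)cc1)N1CCCCC1` differs from compound 2 by one change: 2-((piperidin-1-yl)carbonyl)ethenyl in place of 2-((azetidin-1-yl)carbonyl)ethyl on a saturated chain carbon bound to an amine nitrogen. Going by the values given here, the single measured step, a step that the two limits leave unreadable from compound 1 to compound 2, offers no size to carry over, and no direction either. The expected change is therefore only loosely fixed, at a number no higher from compound 2 to compound 3 (the limit leaves the size open). For compound 3 the estimated value is 25000 nM, with an expected range from 8000 nM to 60000 nM.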

Compound 3, half-maximal inhibitory concentration: 8430 nM
Beside the measured number, compound 3's estimate is 3.0-fold (0.47 log units) above it; low and high end bracket the measured number.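

In this assay, for the compounds shown here, 2-((piperidin-1-yl)carbonyl)ethenyl on a saturated chain carbon bound to an amine nitrogen gives the only actual number so far, with an at least 2.9-fold lower number from compound 2 to compound 3 (0.47 log units; beyond the scatter). Replacing (1-methylethenyl)carbonyl on the amine nitrogen gives an at least 2.9-fold lower number from compound 1 to compound 3 (0.47 log units; beyond the scatter). Both sizes are only minimums, because the other two compounds sit at a limit: the limit of > 25000 nM in this assay, at which 2 of the 3 values shown sit.

The step changes the ring and the double bond together, and the compounds shown do not separate the two. Going by these compounds, how a morpholine amide would read on the same chain also remains open.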